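A few compounds are considered here, and "the series" means these few. Any claim that something is new, unique, unknown or untested is made for them only; others in the source may bear on it.

Measured so far in an ADME assay on microsomes from liver (Homo sapiens) for metabolic stability, read by LC-MS, using NADPH, tested at 1 uM; a higher number here means faster removal of the compound, a lower number slower removal:

- compound 1 `N#Cc1cnc(NC(=O)CCCOc2ccccc2)s1`: 198 mL.min-1.g-1
- compound 2 `N#Cc1cnc(NC(=O)CCCOc2cccc(C(F)(F)F)c2)s1`: 22 mL.min-1.g-1

Of these two compounds, compound 2 has the lower number, at 22 mL.min-1.g-1, and so is removed more slowly. The next compound, compound 3 `N#Cc1cnc(NC(=O)CCCOc2cccc(Cl)c2)s1`, changes one group of compound 2: chloro in place of trifluoromethyl on an aromatic carbon. In words, this is chloro in place of trifluoromethyl on an aromatic carbon.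

For the measured compounds named here, only one measured step bears on this change: a 9.0-fold lower number from compound 1 to compound 2 (0.95 log units; beyond the scatter). That step is beyond the scatter, and it shows what trifluoromethyl in place of hydrogen on an aromatic carbon did in this pair. Going by the values given here, no chloro compound has been measured yet, so the data cannot say how much of that drop a chloro group would keep. A reasonable expectation is that compound 3 keeps part of it, landing above compound 2 but below compound 1 in this assay. The expected change is modest, and the estimated step is a 2.3-fold higher number from compound 2 to compound 3 (0.36 log units; beyond the scatter). The estimate for compound 3 is 50 mL.min-1.g-1, with an expected range of 18 mL.min-1.g-1 to 120 mL.min-1.g-1.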

Compound 3, intrinsic clearance in microsomes in the Homo sapiens assay: 115 mL.min-1.g-1
Compound 3: middle estimate off by 2.3-fold (0.36 log units), on the low side, within the range that was stated.
By their numbers in the Homo sapiens assay, from the lowest: compound 2; then compounds 3 and 1 (each within the scatter of the next).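

In the Homo sapiens assay, putting chloro where trifluoromethyl stood gives a 5.2-fold higher number from compound 2 to compound 3 (0.72 log units; beyond the scatter), so the low number of compound 2 does not come with just any group at this place on the ring. Measured against the unsubstituted ring, chloro in place of hydrogen gives a 1.7-fold lower number from compound 1 to compound 3 (0.24 log units; within the scatter), so this change cannot be told apart from repeat-measurement noise, while the trifluoromethyl group gave a 9.0-fold lower number from compound 1 to compound 2 (0.95 log units; beyond the scatter); of the two groups shown, only trifluoromethyl moves the number beyond the scatter. In a physicochemical assay for solubility, read by nephelometry, at pH 2 (on this read-out higher numbers stand for higher solubility and lower numbers for lower solubility), compound 2 gives < 1600 nM, which is a limit of the assay. In the physicochemical assay, compound 3 gives < 1600 nM, which is also a limit of the assay. In the physicochemical assay, the comparison of compound 2 with compound 3 cannot be read, since neither compound gives a number, only a limit of the assay: the limit of < 1600 nM in the physicochemical assay, at which 2 of the 2 values shown sit.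

Two groups at one place on the ring cannot show what sets trifluoromethyl apart from chloro, and a fluoro, methyl or methoxy group in the same place would test whether the low number belongs to trifluoromethyl alone. On these data alone, it also stays open whether trifluoromethyl would give the same drop on another carbon of the ring, or with a shorter or longer chain joining that ring to the amide.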